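A few compounds are considered here, and "the series" means these few. Any claim that something is new, unique, unknown or untested is made for them only; others in the source may bear on it.

Working notes on the series. Three compounds carry a reading in a toxicity assay on NIH3T3 cells (Mus musculus) for cytotoxicity, read by resazurin assay; a lower number here means that less compound is needed, a higher number that more compound is needed for the effect. Compound 1, `CC(=O)c1ccc(NCc2cncn2Cc2ccc(-c3ccccc3)cc2)cc1-c1ccccc1`, reaches only the limit of the assay there, at > 10000 nM. Compound 2, `COC(=O)c1ccc(NCc2cncn2Cc2cccc(Br)c2)cc1-c1ccccc1`, likewise stops at the limit in this assay, giving > 10000 nM. Going by the values given here, compound 3, `COC(=O)c1ccc(NCc2cncn2Cc2ccccc2N)cc1-c1ccccc1`, is the one member with a number in this assay, at 25000 nM. Among the compounds with values here, the single change among the measured compounds, 2-aminophenyl in place of 3-bromophenyl on a saturated chain carbon bound to an aromatic nitrogen, gives a step that the limit leaves unreadable from compound 2 to compound 3, so its size cannot be read. Because (the limit of > 10000 nM in this assay, at which 2 of the 3 values shown sit), the measured set shows where compound 1 stands only as a limit, with no readable step around it.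

Compound 4, `CNC(=O)c1ccc(NCc2cncn2Cc2ccc(-c3ccccc3)cc2)cc1-c1ccccc1`, differs from compound 1 by methylamino in place of methyl on a carbonyl carbon. Within the data shown here, no measured step touches the carbonyl carbon or its neighbours, so nothing in the set bears on this change, and no step beyond the scatter is expected in this assay in either direction. Compound 4 is therefore expected to sit near the limit of this assay, estimated at 15000 nM, within 5000 nM to 50000 nM. The expected step is a step that the limit leaves unreadable from compound 1 to compound 4, and a limit rather than a number is the likelier outcome.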

Compound 4, half-maximal effective concentration: > 1000 nM
Compound 4: only a limit was reported (the forecaster's own chance of this, stated with the estimate: 60%); the middle value lies beyond the limit too.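

In this assay compound 1 and compound 4 both stop at limits, so no step can be read for methylamino in place of methyl on a carbonyl carbon. The compounds shown leave open how far either compound lies past its limit, and whether this change alters the reading at all.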